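Replacing 3-fluorophenyl with 4-methoxyphenyl on an oxygen

The source may report more compounds than this note shows. Statements on the series, on what has been measured and on what is new or still open speak of the compounds shown alone.

In a functional assay on HT-29 cells (Homo sapiens) for antiproliferative activity, read by sulforhodamine B assay, with a stated time of 48 h (a higher number here means a weaker inhibitor, a lower number a stronger inhibitor), compound 1 (`Cc1cccc(OS(=O)(=O)c2ccc(N3CCN(C)C3=O)cc2)c1`) gives 4300 nM. Compound 2 (`CN1CCN(c2ccc(S(=O)(=O)Oc3cccc(F)c3)cc2)C1=O`) gives > 100000 nM, which is a limit of the assay and not a number. Compound 3 (`CCN1CCN(c2ccc(S(=O)(=O)Oc3cccc(F)c3)cc2)C1=O`) gives > 100000 nM, again only a limit. Compound 3 therefore stands at the limit of > 100000 nM in this assay, at which 2 of the 3 values shown sit.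

Compound 4 (`CCN1CCN(c2ccc(S(=O)(=O)Oc3ccc(OC)cc3)cc2)C1=O`) has 4-methoxyphenyl in place of 3-fluorophenyl on an oxygen. Within the data shown here, two measured steps bear on this change. The chain step gave a step that the two limits leave unreadable from compound 2 to compound 3 and offers no guide. The step on the aromatic ring gave an at least 23-fold higher number from compound 1 to compound 2 (1.36 log units; beyond the scatter), so the group on this ring can matter greatly. Compound 1 at 4300 nM shows that a ring other than 3-fluorophenyl can give a readable value, so a large move towards a lower number is expected. Among the measured compounds shown here, no measured compound carries 4-methoxyphenyl, however, and a result at the limit remains possible. The estimated step is an at least 12-fold lower number from compound 3 to compound 4 (1.09 log units; beyond the scatter). For compound 4 the expected value is 8000 nM, within an estimated range from 1200 nM to 60000 nM.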

Compound 4, half-maximal inhibitory concentration: 60000 nM
For compound 4 the middle estimate is 7.5-fold (0.88 log units) below the measured one, within the range that was stated.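

Changing only the group on this oxygen, with the rest of compound 3 kept, yields a readable value in this assay, so 4-methoxyphenyl in place of 3-fluorophenyl is enough to bring this compound off the limit. Compound 3 has only a limit of the assay and not a number: the limit of > 100000 nM in this assay, at which 2 of the 4 values shown sit. The change is therefore recorded as an at least 1.6-fold lower number from compound 3 to compound 4 (0.22 log units; that floor lies within the scatter), which fixes only the smallest possible size of the move, and the true size may be much larger.

The compounds shown leave open whether 4-fluorophenyl or 3-methoxyphenyl on this oxygen would behave like compound 4, which would separate the effect of the group from that of its place on the ring. They also leave open how an amine or a carboxylic acid on this ring would read.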